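Extending the chain of compound 3

The source may report more compounds than this note shows. Statements on the series, on what has been measured and on what is new or still open speak of the compounds shown alone.

Values from a functional assay on MDA-MB-231 cells (Homo sapiens) for inhibition, read by MTT assay, with a stated time of 72 h (on this read-out higher numbers stand for weaker inhibition and lower numbers for stronger inhibition), follow
- compound 1 `Nc1ncnc2c1c(-c1cnc3[nH]ccc3c1)nn2CCCCCCCCC(=O)NO` gives 11000 nM
- compound 2 `Nc1ncnc2c1c(-c1cnc3[nH]ccc3c1)nn2CCCCCCC(=O)NO` gives 37700 nM
- compound 3 `Nc1nc2cc(-c3nn(CCCCCC(=O)NO)c4ncnc(N)c34)ccc2o1` gives 19000 nM

Compound 3 (19000 nM) lies within the usual scatter of both compound 1 and compound 2. Compound 4 `Nc1nc2cc(-c3nn(CCCCCCC(=O)NO)c4ncnc(N)c34)ccc2o1` keeps the core of compound 3 and has (hydroxycarbamoyl)methyl in place of hydroxycarbamoyl ((hydroxycarbamoyl)methyl in place of hydroxycarbamoyl on a saturated chain carbon, five bonds along the chain from an aromatic nitrogen) on a saturated chain carbon, five bonds along the chain from an aromatic nitrogen. For the measured compounds named here, the only measured change in chain length sits on a different core, where a shorter chain gave a modest step beyond the scatter (a 3.4-fold higher number from compound 1 to compound 2 (0.53 log units; beyond the scatter)). Lengthening should therefore lower the number slightly, with no shift beyond the scatter expected in this assay for this smaller change. The expected step is a 1.4-fold lower number from compound 3 to compound 4 (0.13 log units; within the scatter) in size. The estimate for compound 4 is 14000 nM, within an expected range of 6000 nM to 33000 nM here.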

Compound 4, half-maximal inhibitory concentration: 8430 nM
Beside the measured number, compound 4's estimate is 1.7-fold (0.22 log units) above it; the range from low to high includes it.
By their numbers in this assay, from the lowest: compounds 4, 1, 3 and 2 (each within the scatter of the next, the first and the last beyond it).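

In this assay, (hydroxycarbamoyl)methyl in place of hydroxycarbamoyl gives a 2.3-fold lower number from compound 3 to compound 4 (0.35 log units; beyond the scatter) and so shows that lengthening the chain on this core also moves the number beyond the scatter. With the chain unchanged, swapping the group on the aromatic carbon gives a 4.5-fold lower number from compound 2 to compound 4 (0.65 log units; beyond the scatter) and shows that this part of the molecule also affects the number. No evidence here explains either step. Still open, as far as these compounds go, is whether a longer chain on the core of compound 4 would lower the number further, and whether a carboxylic acid could stand in place of the hydroxycarbamoyl end.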